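A few compounds are considered here, and "the series" means these few. Any claim that something is new, unique, unknown or untested is made for them only; others in the source may bear on it.

Compound 1 `CC(C)OC(=O)c1ccc(NCc2cncn2Cc2ccc(-c3ccccc3)cc2)cc1-c1ccccc1` gives > 10000 nM in a toxicity assay on NIH3T3 cells (Mus musculus) for cytotoxicity, read by resazurin assay (a higher number here means that more compound is needed for the effect, a lower number that less compound is needed), a value that is a limit of the assay and not a number. Compound 2 `COC(=O)c1ccc(NCc2cncn2Cc2ccc(OC)cc2)cc1-c1ccccc1` gives "not determined" (no result reported) in this assay, that is, no result. Compound 3 `CCc1ccc(Cn2cncc2CNc2ccc(-c3nc4ccccc4s3)c(-c3ccccc3)c2)cc1` gives > 1000 nM in this assay.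

For compound 1 the value is a limit of the assay and not a number, so its position can only be given as at the limit of > 10000 nM in this assay, at which 1 of the 3 values shown sits. The value of compound 3 is also a limit, sitting at the limit of > 1000 nM in this assay, at which 1 of the 3 values shown sits. Compound 2 contributes no number.

Compound 4 `COc1ccc(NCc2cncn2Cc2ccc(-c3ccccc3)cc2)cc1-c1ccccc1` differs from compound 1 by methoxy in place of isopropoxycarbonyl on an aromatic carbon. Within the data shown here, no pair of measured compounds shows what this change does. Since compound 1 stands at the limit of > 10000 nM in this assay, at which 1 of the 3 values shown sits, compound 4 is expected to remain there as well, and the expected step of a number no higher from compound 1 to compound 4 (the limit leaves the size open) is none beyond the scatter. Compound 4 is estimated at 10000 nM, with a range from 3000 nM to 30000 nM.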

Compound 4, half-maximal effective concentration: > 1000 nM
Compound 4 was reported as a limit (the forecaster's own chance of this, stated with the estimate: 80%); the middle value is on the limit's open side.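

Compound 1 and compound 4 are both reported in this assay only as limits and not as numbers, so no step can be read between them. The compounds shown leave open whether methoxy in place of isopropoxycarbonyl changes the amount of compound needed for toxicity.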